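Fluorine position shift on the aromatic nitrogen substituent

This account rests on a few compounds, and the source may have more. Where it says the series, first, only, none or still open, it means among the compounds named here.

Compound 1 `Cc1c(C(=O)Nc2ccc(Oc3ccnc4[nH]ccc34)c(F)c2)nnn1-c1ccccc1F` and compound 2 `Cc1c(C(=O)Nc2ccc(Oc3ccnc4[nH]ccc34)c(F)c2)nnn1-c1ccc(F)cc1` share one core; compound 3 `O=C(Nc1ccc(Oc2ccnc3[nH]ccc23)cc1)c1nnn(-c2ccccc2F)c1C(F)(F)F` and compound 4 `O=C(Nc1ccc(Oc2ccnc3[nH]ccc23)cc1)c1nnn(-c2ccc(F)cc2)c1C(F)(F)F` share another, and how the two cores differ is not broken down here. In a functional assay on PC-3 cells (Homo sapiens) for cytotoxicity, read by MTT assay, with a stated time of 72 h (on this read-out higher numbers stand for weaker inhibition and lower numbers for stronger inhibition), compound 1 gives 3240 nM, compound 2 gives 4350 nM and compound 3 gives 3690 nM. The change from compound 1 to compound 2 is 4-fluorophenyl in place of 2-fluorophenyl on an aromatic nitrogen, and the step it made was a 1.3-fold higher number from compound 1 to compound 2 (0.13 log units; within the scatter). The change from compound 3 to compound 4 is 4-fluorophenyl in place of 2-fluorophenyl on an aromatic nitrogen. It is the same kind of change, not the same: in the first pair the place is next to the ring atom that bears a methyl group, in the second pair it is next to the ring atom that bears a trifluoromethyl group. The expectation for compound 4 rests only on the measured step of a 1.3-fold higher number from compound 1 to compound 2 (0.13 log units; within the scatter), with no second instance to check it against. A step of about the same size is expected here, a 1.3-fold higher number from compound 3 to compound 4 (0.11 log units; within the scatter). Compound 4 is therefore expected near 4700 nM in this assay, between 2200 nM and 10000 nM.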

Compound 4, half-maximal inhibitory concentration: 2830 nM
Beside the measured number, compound 4's estimate is 1.7-fold (0.22 log units) above it, within the range that was stated.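

In this assay, 4-fluorophenyl in place of 2-fluorophenyl on an aromatic nitrogen of the core bearing a trifluoromethyl group gives a 1.3-fold lower number from compound 3 to compound 4 (0.12 log units; within the scatter). The steps on the two cores point in opposite directions, but neither step nor the gap between them goes beyond the scatter, so the opposite signs carry no weight and the change can be read only as leaving the number unmoved on both cores: the same change on two cores in this assay, a 1.3-fold higher number (0.13 log units; within the scatter) from compound 1 to compound 2 and a 1.3-fold lower number (0.12 log units; within the scatter) from compound 3 to compound 4, 1.8-fold (0.24 log units) apart, within the scatter of two such steps. This shows that the null result carries across these two cores in this assay, but it does not show that the change would be equally silent on any other core or in any other read-out, since two pairs make no rule.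

The compounds shown leave open whether a phenyl carrying an amine, a methoxy group or a carboxylic acid in place of the fluorine would move the number beyond the scatter. They also leave open what a longer alkyl chain would do in place of the methyl or the trifluoromethyl.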